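Benzyloxy to allyloxy swap: cytotoxicity notes on the series

The source may hold more compounds than are shown below. What is called first, only, known or untested is meant among the compounds shown, and "the series" means these compounds.

Measured so far:
compound 1, `CC(C(=O)NOCc1ccccc1)N1C(=O)CSC1=O`: > 128000 nM
compound 2, `C=CCONC(=O)C(C)N1C(=O)CSC1=O`: > 128000 nM
compound 3, `CCCC/C=C1\SC(=O)N(C(C)C(=O)NOCc2ccccc2)C1=O`: 43900 nM

In an ADME assay on RAW264.7 cells (Mus musculus) for cytotoxicity, read by neutral red uptake, with a stated time of 24 h (on this read-out lower numbers stand for higher toxicity in this test and higher numbers for lower toxicity in this test), compound 1 reaches only a limit of the assay, > 128000 nM. Compound 2 likewise gives only a limit, > 128000 nM. Within the data shown here, compound 3 is the one compound with a number in this assay, at 43900 nM. The change from compound 1 to compound 2 is vinyl in place of phenyl on a saturated chain carbon bound to an oxygen and its step is a step that the two limits leave unreadable from compound 1 to compound 2; both values sit at the limit of > 128000 nM in this assay, at which 2 of the 3 values shown sit. The difference between the core of compound 1 and the core of compound 3 is not broken down here.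

Compound 4, `C=CCONC(=O)C(C)N1C(=O)S/C(=C\CCCC)C1=O`, is not yet measured. It differs from compound 3 by vinyl in place of phenyl on a saturated chain carbon bound to an oxygen, the same change as from compound 1 to compound 2, at the same place.

Among the measured compounds shown here, the step from compound 3 to compound 4 in this assay is estimated as a 1.1-fold higher number from compound 3 to compound 4 (0.06 log units; within the scatter), taken as small, because the earlier step that the two limits leave unreadable from compound 1 to compound 2 gives no readable size and the only anchor is compound 3 at 43900 nM. Compound 4 is therefore expected to give about 50000 nM, estimated between 15000 nM and 128000 nM.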

Compound 4, half-maximal cytotoxic concentration: > 128000 nM
Compound 4: no number, only a limit; the forecaster's own chance of this, stated with the estimate: 30%; middle value at least 2.5-fold (0.40 log units) from the limit.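

In this assay the change from benzyloxy to allyloxy gives an at least 2.9-fold higher number from compound 3 to compound 4 (0.46 log units; beyond the scatter) and so lies beyond the scatter on the core of compound 3. Among these compounds, the same change on the core of compound 1 cannot be read, so the series offers no two readable steps to compare, and nothing here shows that the size of the step carries from one core to the other. Compound 4 gives only a limit, and the full size of its step remains unread: the limit of > 128000 nM in this assay, at which 3 of the 4 values shown sit.

The compounds shown leave open how other groups would behave on the saturated chain carbon bound to an oxygen, for example an amine, a carboxylic acid or a longer chain in place of the phenyl. They also leave open whether the change would give a readable step on any core other than the core of compound 3.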